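The source may hold more compounds than are shown below. What is called first, only, known or untested is meant among the compounds shown, and "the series" means these compounds.

In a physicochemical assay for solubility, in phosphate buffer, measured as kinetic solubility, at pH 7.4 (on this read-out higher numbers stand for higher solubility and lower numbers for lower solubility), compound 1 `Cc1ccc(C)c(-c2nc(CN3CCC(C(=O)NCCCN4C[C@H](C)C[C@H](C)C4)CC3)c(C)o2)c1` gives 56.1 ug/mL. Compound 2 `Cc1cccc(-c2nc(CN3CCC(C(=O)NCCCN4C[C@H](C)C[C@H](C)C4)CC3)c(C)o2)c1` gives > 69 ug/mL, which is a limit of the assay and not a number. Among the measured compounds shown here, the only measured step shows an at least 1.2-fold higher number from compound 1 to compound 2 (0.08 log units; that floor lies within the scatter), with hydrogen in place of methyl on an aromatic carbon. Compound 3 `COc1cccc(C)c1-c1nc(CN2CCC(C(=O)NCCCN3C[C@H](C)C[C@H](C)C3)CC2)c(C)o1` differs from compound 2 by 2-methoxy-6-methylphenyl in place of 3-methylphenyl on an aromatic carbon. For the measured compounds named here, no measured step brings in a 2-methoxy-6-methylphenyl group, so no step beyond the scatter is expected in this assay, and the estimated step is an at least 1.1-fold lower number from compound 2 to compound 3 (0.06 log units; that floor lies within the scatter). Compound 3 is expected at 60 ug/mL, within an estimated range of 30 ug/mL to 90 ug/mL.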

Compound 3, solubility: > 73 ug/mL
Compound 3: a limit, no number (the forecaster's own chance of this, stated with the estimate: 40%); at least 1.2-fold (0.08 log units) between middle value and limit.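

In this assay compound 3 gives > 73 ug/mL, a limit of the assay and not a number, so with 2-methoxy-6-methylphenyl and its hydrogen-bond acceptor on this position the read-out again yields no number. Replacing 2,5-dimethylphenyl with 2-methoxy-6-methylphenyl gives an at least 1.3-fold higher number from compound 1 to compound 3 (0.11 log units; that floor lies within the scatter). The step between compound 2 and compound 3 cannot be read, so no order between them can be stated.

Still open, going by these compounds, is how far either limit lies from a measured number, and whether an amine or a carboxylic acid in place of the methoxy group would give a readable value in this assay.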